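Ester to Acid on Two Related Cytotoxic Cinnamates

This account rests on a few compounds, and the source may have more. Where it says the series, first, only, none or still open, it means among the compounds named here.

Measured compounds:
compound 1, `CCOC(=O)/C=C/c1ccc(OCc2nc(C)c(C)nc2C)c(O)c1`, 139000 nM
compound 2, `CCOC(=O)/C=C/c1ccccc1OCc1nc(C)c(C)nc1C`, 1540000 nM
compound 3, `Cc1nc(C)c(COc2ccc(/C=C/C(=O)O)cc2O)nc1C`, 46000 nM

Compounds 1, 2 and 3 were tested in a functional assay on ECV-304 cells (Homo sapiens) for cytotoxicity, read by MTT assay, with stated times of 24 h and 12 h; a higher number here means that more compound is needed for the effect, a lower number that less compound is needed. Compound 1 gave 139000 nM, compound 3 gave 46000 nM, and compound 2 gave 1540000 nM, the highest of the three numbers. The difference between the core of compound 1 and the core of compound 2 is not broken down here.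

Compounds 1 and 3 differ in one place: hydrogen in place of ethyl on an oxygen next to a carbonyl group. That change gave a 3.0-fold lower number from compound 1 to compound 3 (0.48 log units; beyond the scatter). Compound 4, `Cc1nc(C)c(COc2ccccc2/C=C/C(=O)O)nc1C`, is not yet measured in this assay; it stands to compound 2 as compound 3 stands to compound 1, since (hydrogen in place of ethyl on an oxygen next to a carbonyl group). The two changes are the same.

Because the same change is expected to move the number in the same direction as a 3.0-fold lower number from compound 1 to compound 3 (0.48 log units; beyond the scatter), compound 4 is expected to show a 3.1-fold lower number from compound 2 to compound 4 (0.49 log units; beyond the scatter). That rests on a single measured pair, so the expectation is loose. Compound 4 is estimated at 500000 nM, most likely between 200000 nM and 1500000 nM.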

Compound 4, half-maximal effective concentration: 499000 nM
The estimate for compound 4 lay 1.0-fold (0.00 log units) above the measured number, and the stated range covers the measured number.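

In this assay, the change from ethoxycarbonyl to carboxy gave a 3.1-fold lower number from compound 2 to compound 4 (0.49 log units; beyond the scatter), and this step matched the one already seen on the other core: the same change on two cores in this assay, a 3.0-fold lower number (0.48 log units; beyond the scatter) from compound 1 to compound 3 and a 3.1-fold lower number (0.49 log units; beyond the scatter) from compound 2 to compound 4, 1.0-fold (0.01 log units) apart, within the scatter of two such steps Across these two pairs, the change therefore carried from one core to the other with its direction and size intact, even though the two ethyl esters themselves stand far apart in their numbers. For the compounds shown here, this does not show that the change would behave the same way on any further core, since it rests on only two pairs in a single cell assay, and it gives no explanation of why the number falls.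

All the compounds shown carry either the 2-(ethoxycarbonyl)ethenyl or the 2-carboxyethenyl group, which leaves open how a methyl ester, an amide or a longer chain in that place would read. On these data alone, it also remains open whether the same step would hold on a core bearing an amine or a halogen.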